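A Stereocentre Flip on a Lipase Inhibitor

The source may report more compounds than this note shows. Statements on the series, on what has been measured and on what is new or still open speak of the compounds shown alone.

Among the measured compounds shown here, compound 2 `CCCCCCCCCCCCCCCCO[P@]1(=O)OC[C@@H]2COC(=O)C2=C(C)O1` holds the only real number in an assay on isolated protein for inhibition of Hormone-sensitive lipase (Rattus norvegicus), read by scintillation counting; a higher number here means a weaker inhibitor, a lower number a stronger inhibitor: compound 2 gives 25 nM. Compound 1 `CO[P@]1(=O)OC[C@H]2COC(=O)C2=C(C)O1` reached only a limit of this assay, > 100000 nM, which is the limit of > 100000 nM in this assay, at which 1 of the 2 values shown sits. Compound 3 `CCCCCCCCCCCCCCCCO[P@]1(=O)OC[C@H]2COC(=O)C2=C(C)O1` differs from compound 2 in one place: the two compounds have the same atoms and bonds and differ only in configuration as drawn: 1 of 2 stereo elements differ; a stereocentre at a saturated ring carbon is drawn S in compound 2 and R in compound 3. For the measured compounds named here, no measured pair isolates such a change, so its size is open; a change of configuration at a ring carbon can leave potency unchanged or weaken it considerably. Compound 3 is expected to be a somewhat weaker inhibitor, at an estimated 120 nM, with a range of 20 nM to 2000 nM. The expected step is a 4.8-fold higher number from compound 2 to compound 3 (0.68 log units; beyond the scatter).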

Compound 3, half-maximal inhibitory concentration: 420 nM
The estimate for compound 3 lay 3.5-fold (0.54 log units) below the measured number; the measured number falls inside the stated range.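

In this assay, switching one stereocentre at a saturated ring carbon from S to R gives a 17-fold higher number from compound 2 to compound 3 (1.23 log units; beyond the scatter), so potency here depends on the configuration at this position, and the S form as drawn is the stronger inhibitor. That step can be assigned to this single centre alone because nothing else changes: the fact that compounds 2 and 3 differ only in the configuration as drawn

On these data alone, the other stereo element remains untested on its own. Also open, as far as these compounds go, is whether this preference would hold with a shorter chain, or with a chain carrying an amine or a carboxylic acid.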